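The source may hold more compounds than are shown below. What is called first, only, known or untested is meant among the compounds shown, and "the series" means these compounds.

The shared core of compound 1, `CCCCCCCCN(C)C(=O)Cn1cc(Cc2cnc(OC)nc2)c(=O)nc1SCc1ccc(F)cc1`, carries a methoxy group; in a functional assay on a cell-free system (plasma, Oryctolagus cuniculus) for inhibition of platelet-activating factor acetylhydrolase (Homo sapiens), tested at 100 nM (a higher number here means more inhibition at the concentration tested (going by the name of the read-out), a lower number less inhibition), compound 1 gives 13%. Compound 2, `CCCCCCCCN(C)C(=O)Cn1cc(Cc2cnc(OCC)nc2)c(=O)nc1SCc1ccc(F)cc1`, extends this to an ethoxy group, and in this assay compound 2 gives 7%. For the measured compounds named here, compound 2 therefore stands lowest of the two numbers measured, though its only neighbour is compound 1, and the change a number 6 percentage points lower from compound 1 to compound 2 (within the scatter) lies within the scatter, so the two values cannot be ordered.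

Compound 3, `CCCCCCCCN(C)C(=O)Cn1cc(Cc2cnc(OCc3ccccc3)nc2)c(=O)nc1SCc1ccc(F)cc1`, is unmeasured. It differs from compound 2 by phenyl in place of methyl on a saturated chain carbon bound to an oxygen on an aromatic ring. Going by the values given here, the one measured step at this position, a number 6 percentage points lower from compound 1 to compound 2 (within the scatter), is the only one that bears on the new change, and it was within the scatter. Among the compounds with values here, it is a much smaller change than the one to compound 3, so it gives little guidance on size, but it gives no reason to expect a step beyond the scatter in either direction in this assay. Compound 3 is therefore expected to give about 10%, between 0% and 30%, which means an estimated step of a number 3 percentage points higher from compound 2 to compound 3 (within the scatter).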

Compound 3, a percentage reported as inhibition, at one concentration (the size of the read-out at that concentration, not a potency): 8%
Compound 3: middle estimate off by 2 percentage points, on the high side, and the stated range covers the measured number.
By their numbers in this assay, from the lowest: compounds 2, 3 and 1 (each within the scatter of the next).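

In this assay, phenyl in place of methyl on a saturated chain carbon bound to an oxygen on an aromatic ring gives a number 1 percentage points higher from compound 2 to compound 3 (within the scatter), and phenyl in place of hydrogen at that same carbon gives a number 5 percentage points lower from compound 1 to compound 3 (within the scatter). The earlier pair covered only the change from methoxy to ethoxy, whereas this result covers a far larger change, with one six-membered aromatic ring of carbon only entering at this place, and even that step does not leave the scatter. The methoxy, ethoxy and benzyloxy compounds therefore cannot be told apart in this assay, so no order among them can be read from these numbers. Nothing in the data at hand bears on the reason for this result.

Going by these compounds, whether a carboxylic acid, an amine or a longer chain in place of the phenyl would give a step beyond the scatter remains open. Also open, on these data alone, is whether compound 1, compound 2 and compound 3 would separate at another concentration, since the read-out gives the size of the inhibition at one concentration and not a potency.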